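The compounds below may be only part of what the source reports. "The series", "measured", "known", "first", "only" and "open" are said of these compounds alone.

Measured in a functional assay on HepG2 cells (Homo sapiens) for antiproliferative activity, read by MTT assay, with a stated time of 48 h; on this read-out higher numbers stand for weaker inhibition and lower numbers for stronger inhibition:
- compound 1 `CC(=O)N1N=C(c2ccc3ccccc3c2)OC1c1ccc(F)cc1`: 1.82 ug/mL
- compound 2 `CC(=O)N1N=C(c2ccc3ccccc3c2)OC1c1ccccc1O`: 1.84 ug/mL
- compound 3 `CC(=O)N1N=C(c2ccc3ccccc3c2)OC1c1ccccn1`: 5.26 ug/mL

Compound 3 has the highest number of the three, and its gaps to the other two lie beyond the scatter. Compound 4 `CC(=O)N1N=C(c2ccc3ccccc3c2)OC1c1ccc(C)cc1` carries 4-methylphenyl in place of pyridin-2-yl on a saturated ring carbon.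

Among the measured compounds shown here, two measured steps bear on this change, both with pyridin-2-yl entering, the reverse of the step considered here. One is a 2.9-fold higher number from compound 1 to compound 3 (0.46 log units; beyond the scatter), and the other is a 2.9-fold higher number from compound 2 to compound 3 (0.46 log units; beyond the scatter). The two phenyl-bearing compounds themselves show a 1.0-fold higher number from compound 1 to compound 2 (0.00 log units; within the scatter). For the measured compounds named here, no compound with 4-methylphenyl has been measured, so this comparison is indirect and rests on only two phenyl-bearing compounds. Leaving pyridin-2-yl for a substituted phenyl is therefore expected to give a modest step to a lower number in this assay, about as large as those two steps. The expected change is a 2.5-fold lower number from compound 3 to compound 4 (0.40 log units; beyond the scatter). Compound 4 is estimated at 2.1 ug/mL, with an expected range of 0.9 ug/mL to 5 ug/mL.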

Compound 4, half-maximal inhibitory concentration: 2.26 ug/mL
Beside the measured number, compound 4's estimate is 1.1-fold (0.03 log units) below it; the measured number falls inside the stated range.
By their numbers in this assay, from the lowest: compounds 1, 2 and 4 (each within the scatter of the next); then compound 3.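

In this assay, a third substituted phenyl on this saturated ring carbon gives a 2.3-fold lower number from compound 3 to compound 4 (0.37 log units; beyond the scatter) and so joins the earlier two on the same side of the gap to pyridin-2-yl, this time with an all-carbon group that has no hydrogen-bond acceptor. The three phenyl-bearing compounds cannot be told apart, with a 1.2-fold higher number from compound 2 to compound 4 (0.09 log units; within the scatter) and a 1.2-fold higher number from compound 1 to compound 4 (0.09 log units; within the scatter) both within the scatter, so methyl in place of fluoro on the aromatic carbon brings no readable change in this assay. Nothing at hand explains why pyridin-2-yl stands apart from the phenyl groups.

Still open, going by these compounds, is whether the higher number follows the ring nitrogen wherever it sits, as pyridin-3-yl or pyridin-4-yl on the same carbon would show. Also open, on these data alone, is whether a phenyl carrying an amine or a carboxylic acid stays with the phenyl-bearing compounds or departs from them.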